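This account rests on a few compounds, and the source may have more. Where it says the series, first, only, none or still open, it means among the compounds named here.

Measured compounds in a functional assay on KB cells (Homo sapiens) for cytotoxicity, read by MTT assay, with a stated time of 72 h; on this read-out higher numbers stand for an effect only at larger amounts of compound and lower numbers for an effect already at smaller amounts:
Compound 1 `CCc1cccc2c(OC)c(-c3occ(C)c3C(=O)NC)ccc12` gives > 10 ug/mL, which is a limit of the assay.
Compound 2 `CCc1cccc2c(OC)c(-c3occ(C)c3COC)ccc12` gives > 10 ug/mL, which is a limit of the assay.
Compound 3 `CCOCc1c(C)coc1-c1ccc2c(CC)cccc2c1OC` gives > 10 ug/mL, which is a limit of the assay.

None of the three values is a number; all sit at the limit of > 10 ug/mL in this assay, at which 3 of the 3 values shown sit. Compound 3 therefore stands only at a limit in this assay, and the two other measured compounds stand at the same limit, so no order among them can be read. The change from compound 3 to compound 4 `CCc1cccc2c(OC)c(-c3occ(C)c3CBr)ccc12` is bromo in place of ethoxy on a saturated chain carbon bound to an aromatic carbon. The closest measured step alters the same group, a step that the two limits leave unreadable from compound 2 to compound 3, and the steps a step that the two limits leave unreadable from compound 1 to compound 2 and a step that the two limits leave unreadable from compound 1 to compound 3 are equally unreadable because every value involved sits at the limit of > 10 ug/mL in this assay, at which 3 of the 3 values shown sit. Among the compounds with values here, the measured steps thus give no size and no direction for the step in this assay, and an outcome at the limit again is as likely as a number. Compound 4 is expected at 10 ug/mL, with a range from 3 ug/mL to 40 ug/mL. This estimate amounts to an expected step of a number no higher from compound 3 to compound 4 (the limit leaves the size open), with a fair chance that only a limit is reported.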

Compound 4, concentration for half-maximal effect: > 10 ug/mL
Compound 4 was reported as a limit; the forecaster's own chance of this, stated with the estimate: 50%; the middle value lies on the limit itself.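

In this assay compound 4 gives > 10 ug/mL, which is a limit of the assay. Within the data shown here, no step linking compound 4 to compound 1, compound 2 or compound 3 can be read: the limit of > 10 ug/mL in this assay, at which 4 of the 4 values shown sit. The compounds shown leave open what size or direction any of these changes has in this assay.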